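A few compounds are considered here, and "the series" means these few. Any claim that something is new, unique, unknown or untested is made for them only; others in the source may bear on it.

Three compounds sharing one core have been measured in an assay on microsomes from liver for inhibition of 3-hydroxy-3-methylglutaryl-coenzyme A reductase (Rattus norvegicus); a higher number here means a weaker inhibitor, a lower number a stronger inhibitor:

Compound 1, `CCN(Cc1ccccc1)C(=O)c1nn(-c2ccc(F)cc2)c(OC[C@@H](O)C[C@@H](O)CC(=O)O)c1C(C)C`, gives 14 nM.
Compound 2, `Cc1cccc(CNC(=O)c2nn(-c3ccc(F)cc3)c(OC[C@@H](O)C[C@@H](O)CC(=O)O)c2C(C)C)c1`, gives 4.9 nM.
Compound 3, `CC(C)c1c(C(=O)N2CCCCC2)nn(-c2ccc(F)cc2)c1OC[C@@H](O)C[C@@H](O)CC(=O)O`, gives 47 nM.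

Compound 3 carries the highest of these three numbers, so it is the weakest inhibitor of the set: compound 1 sits nearer to it, compound 2 furthest away. The steps among the three all concern the group on the carbonyl carbon attached to the core. Replacing benzyl(ethyl)amino with (3-methylbenzyl)amino gave a 2.9-fold lower number from compound 1 to compound 2 (0.46 log units; beyond the scatter), replacing it with piperidin-1-yl gave a 3.4-fold higher number from compound 1 to compound 3 (0.53 log units; beyond the scatter), and going from (3-methylbenzyl)amino to piperidin-1-yl gave a 9.6-fold higher number from compound 2 to compound 3 (0.98 log units; beyond the scatter).

Compound 4, `COc1ccccc1CNC(=O)c1nn(-c2ccc(F)cc2)c(OC[C@@H](O)C[C@@H](O)CC(=O)O)c1C(C)C`, differs from compound 3 by (2-methoxybenzyl)amino in place of piperidin-1-yl on a carbonyl carbon. This is the reverse of the kind of change seen from compound 2 to compound 3, with a methoxy group rather than a methyl on the aromatic ring, and in a different place on it. The closest guide is therefore the step of a 9.6-fold higher number from compound 2 to compound 3 (0.98 log units; beyond the scatter) run backwards, tempered by the fact that the substituent is not the same. A sizeable step downward in this assay is expected, roughly a 6.7-fold lower number from compound 3 to compound 4 (0.83 log units; beyond the scatter). Compound 4 is thus estimated at 7 nM, with a likely range from 3 nM to 18 nM.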

Compound 4, half-maximal inhibitory concentration: 22 nM
Beside the measured number, compound 4's estimate is 3.1-fold (0.50 log units) below it, and the stated range ends below it.
By their numbers in this assay, from the lowest: compound 2; then compounds 1 and 4 (each within the scatter of the next); then compound 3.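

Swapping the piperidin-1-yl group for (2-methoxybenzyl)amino lowers the number only modestly (a 2.1-fold lower number from compound 3 to compound 4 (0.33 log units; beyond the scatter)), yet every compound with a benzyl-type group on the carbonyl carbon now has a lower number than compound 3, and none of the compounds goes against this. Keeping the amide hydrogen does not by itself give the lowest number: compound 4 has that hydrogen and compound 1 does not, yet the two cannot be told apart (a 1.6-fold higher number from compound 1 to compound 4 (0.20 log units; within the scatter)). The ring on the benzyl group also matters, since 2-methoxyphenyl in place of 3-methylphenyl costs a clear amount (a 4.5-fold higher number from compound 2 to compound 4 (0.65 log units; beyond the scatter)), although no measurement shown explains why any of these numbers moves as it does.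

That last change altered both the substituent and its place on the ring, so the compounds shown cannot separate the effect of methoxy against methyl from the effect of where the group sits. A plain benzylamino group, with neither methyl nor methoxy on the ring, would show whether either substituent raises or lowers the number relative to the bare ring.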